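The source may report more compounds than this note shows. Statements on the series, on what has been measured and on what is new or still open speak of the compounds shown alone.

Measured so far:
Compound 1, `Cn1cc(-c2ccc(NC(=O)c3cn(CC4CCOCC4)cc(-c4cccc(F)c4)c3=O)cc2)c2c(N)ncnc21`, gives 3 nM in an assay on isolated protein for inhibition of tyrosine-protein kinase receptor UFO (Homo sapiens), read by ELISA; a lower number here means a stronger inhibitor, a higher number a weaker inhibitor.
Compound 2, `Cn1cc(-c2ccc(NC(=O)c3cn(CC4CCOCC4)cc(-c4ccc(Cl)cc4)c3=O)cc2)c2c(N)ncnc21`, gives 0.2 nM in this assay.

Going by the values given here, of the two numbers in this assay, compound 2 holds the lower one; its only neighbour is compound 1, whose number is higher by the step of a 15-fold lower number from compound 1 to compound 2 (1.18 log units; beyond the scatter). That step changed both the halogen and its position on the ring at once, so it does not separate the two effects.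

Compound 3, `Cn1cc(-c2ccc(NC(=O)c3cn(CC4CCOCC4)cc(-c4ccc(C(F)(F)F)cc4)c3=O)cc2)c2c(N)ncnc21`, awaits measurement. It differs from compound 2 by trifluoromethyl in place of chloro on an aromatic carbon, a change on the same ring, para to a large group, where the earlier step also acted. Among the compounds with values here, no measured pair compares two groups at this one place, so the earlier step shows only that this ring position responds strongly to substitution, not in which direction a trifluoromethyl will move the number. With compound 2 already at the low end, a modest rise is the more likely outcome. Compound 3 is expected to give about 0.5 nM, within a range from 0.1 nM to 3 nM. That corresponds to an expected 2.5-fold higher number from compound 2 to compound 3 (0.40 log units; beyond the scatter).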

Compound 3, half-maximal inhibitory concentration: 0.4 nM
Compound 3: middle estimate off by 1.3-fold (0.10 log units), on the high side; measured number inside the range.
By their numbers in this assay, from the lowest: compounds 2 and 3 (each within the scatter of the next); then compound 1.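

In this assay, putting trifluoromethyl, with 4 heavy atoms, in place of chloro, with 1, para to a large group gives a 2.0-fold higher number from compound 2 to compound 3 (0.30 log units; within the scatter), so this place accepts either group with no difference that can be read between compound 2 and compound 3. The earlier compounds offered only a single step, whereas a 7.5-fold lower number from compound 1 to compound 3 (0.88 log units; beyond the scatter) now shows a second case in which a group para to a large group stands apart from 3-fluorophenyl, though this step is listed as modest where the first was large, and among these three compounds neither 4-substituted ring goes against that pairing. No supporting data are available to explain why the two groups read alike here or why both differ from 3-fluorophenyl.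

Both steps from compound 1 still change the group and its place on the ring together, so the part played by each remains unresolved. As far as these compounds go, it also remains open whether this place would accept an amine, a carboxylic acid or a longer chain as it accepts chloro and trifluoromethyl.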